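Swapping Trifluoromethyl for Fluoro: Expected Effect on Cytotoxicity

The compounds below may be only part of what the source reports. "The series", "measured", "known", "first", "only" and "open" are said of these compounds alone.

Compound 3 `CCn1cc(C(=O)O)c(=O)c2cc(F)c(N3CCN(/C=N/NC(=O)c4ccc(C(F)(F)F)cc4)CC3)cc21` was assessed in an ADME assay on HepG2 cells (Homo sapiens) for cytotoxicity, read by MTT assay; on this read-out higher numbers stand for weaker inhibition and lower numbers for stronger inhibition. There compound 3 gives > 37300 nM, which is a limit of the assay rather than a number. Its nearest measured relative, compound 1 `O=C(N/N=C/N1CCN(c2cc3c(cc2F)c(=O)c(C(=O)O)cn3C2CC2)CC1)c1ccc(C(F)(F)F)cc1`, carries cyclopropyl on the aromatic nitrogen where compound 3 carries ethyl, and in this assay compound 1 gives 347000 nM. With one side a limit, a step that the limit leaves unreadable from compound 1 to compound 3. Among the compounds with values here, the only other measured compound, compound 2 `O=C(N/N=C/N1CCN(c2cc3c(cc2F)c(=O)c(C(=O)O)cn3C2CC2)CC1)c1ccc(F)cc1`, differs from compound 1 by fluoro in place of trifluoromethyl on an aromatic carbon. In this assay compound 2 gives > 1280000 nM, again a limit. That swap produced an at least 3.6-fold higher number from compound 1 to compound 2 (0.56 log units; beyond the scatter). Compound 4 `CCn1cc(C(=O)O)c(=O)c2cc(F)c(N3CCN(/C=N/NC(=O)c4ccc(F)cc4)CC3)cc21` applies the same exchange to compound 3: fluoro in place of trifluoromethyl on an aromatic carbon. Within the data shown here, since the one measured instance of this change, an at least 3.6-fold higher number from compound 1 to compound 2 (0.56 log units; beyond the scatter), was a rise to a limit, compound 4 is expected to show a step that the limit leaves unreadable from compound 3 to compound 4, likely ending at a limit as well. Compound 4 is estimated at 1000000 nM, within a range from 300000 nM to 5000000 nM.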

Compound 4, half-maximal inhibitory concentration: > 797000 nM
Compound 4: no number, only a limit (the forecaster's own chance of this, stated with the estimate: 70%); the middle value does not contradict the limit.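

Compound 4 gives only a limit, as do compound 2 and compound 3, so its steps from compound 3 and from compound 2 cannot be read. The compounds shown leave open how large either exchange, fluoro for trifluoromethyl or ethyl for cyclopropyl, truly is between these pairs in this assay.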